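The source may hold more compounds than are shown below. What is called first, only, known or untested is meant among the compounds shown, and "the series" means these compounds.

Measured compounds:
compound 1 `CC/C(=C(/c1ccc(/C=C/C(=O)O)cc1)c1ccc2[nH]ncc2c1)c1ccccc1` — 7.2 nM
compound 2 `CCCC/C(=C(/c1ccc(/C=C/C(=O)O)cc1)c1ccc2[nH]ncc2c1)c1ccccc1` — 10 nM
compound 3 `O=C(O)/C=C/c1ccc(/C(=C(/CCF)c2ccccc2)c2ccc3[nH]ncc3c2)cc1` — 2.1 nM

In a functional assay on MCF7 cells (Homo sapiens) for cytotoxicity, read by CellTiter-Glo, with a stated time of 5 days (on this read-out higher numbers stand for weaker inhibition and lower numbers for stronger inhibition), compound 2 gives the highest of the three numbers; its nearest neighbour is compound 1, with a 1.4-fold higher number from compound 1 to compound 2 (0.14 log units; within the scatter), and its furthest is compound 3, with a 4.8-fold lower number from compound 2 to compound 3 (0.68 log units; beyond the scatter). Compound 4 `CC(C)/C(=C(/c1ccc(/C=C/C(=O)O)cc1)c1ccc2[nH]ncc2c1)c1ccccc1` has not yet been measured. It differs from compound 2 by isopropyl in place of butyl on a double-bonded chain carbon bound to an aromatic carbon and a double-bonded chain carbon. Of the measured steps, the one that bears most on this change is the lengthening of the same chain from compound 1 to compound 2, which gave a 1.4-fold higher number from compound 1 to compound 2 (0.14 log units; within the scatter), a step within the scatter. The fluoro steps, a 3.4-fold lower number from compound 1 to compound 3 (0.54 log units; beyond the scatter) and a 4.8-fold lower number from compound 2 to compound 3 (0.68 log units; beyond the scatter), concern a different kind of substituent and speak less directly to a branched alkyl in place of a straight one. On this basis no step beyond the scatter is expected in this assay for the change from compound 2 to compound 4, and the number for compound 4 is estimated at 8 nM, with a range from 3.5 nM to 20 nM, which means an expected step of a 1.3-fold lower number from compound 2 to compound 4 (0.10 log units; within the scatter).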

Compound 4, half-maximal inhibitory concentration: 4 nM
Compound 4: the middle estimate sits 2.0-fold (0.30 log units) above what was measured, and the stated range covers the measured number.
By their numbers in this assay, from the lowest: compounds 3, 4, 1 and 2 (each within the scatter of the next, the first and the last beyond it).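

In this assay, the change from butyl to isopropyl on the double-bonded chain carbon gives a 2.5-fold lower number from compound 2 to compound 4 (0.40 log units; beyond the scatter) and so shows that an all-carbon group at this position can shift the number beyond the scatter, which the lengthening from compound 1 to compound 2 did not do. The isopropyl compound is not separated from its other two neighbours, with a 1.8-fold lower number from compound 1 to compound 4 (0.26 log units; within the scatter) and also a 1.9-fold higher number from compound 3 to compound 4 (0.28 log units; within the scatter) so that, among these compounds, isopropyl and 2-fluoroethyl cannot be told apart in this read-out. Nothing available here accounts for the step from butyl to isopropyl.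

Whether the step depends on branching itself or on the shorter chain remains open, since a propyl or a tert-butyl group is not among the compounds shown. On these data alone, it is equally open how a cyclopropyl ring or a fluorine on a branched chain would read at this position.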